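Aminomethylbenzoyl amide in place of pyrazole sulfonamide

The source may hold more compounds than are shown below. What is called first, only, known or untested is meant among the compounds shown, and "the series" means these compounds.

Compounds measured in an assay on isolated protein for inhibition of Rho-associated protein kinase 1 (Homo sapiens), read by scintillation counting, radiometric assay and 33P incorporation, with a stated time of 40 min, in the presence of a further agent that is not named here; on this read-out lower numbers stand for stronger inhibition and higher numbers for weaker inhibition:
compound 1 `Cc1cc(C(=O)Nc2cccc(NC(=O)COc3ccc4c(=O)ccoc4c3)c2)ccc1C(F)(F)F` gives 460 nM;
compound 2 `O=C(COc1ccc2c(=O)ccoc2c1)Nc1cccc(NC(=O)c2cnc(C(F)(F)F)s2)c1` gives 160 nM;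
compound 3 `Cn1ccc(S(=O)(=O)Nc2cccc(NC(=O)COc3ccc4c(=O)ccoc4c3)c2)n1` gives > 10000 nM.

For compound 3 the value is only a limit of this assay (the limit of > 10000 nM in this assay, at which 1 of the 3 values shown sits), so compound 3 stands at the weak end of the three. Compound 4 `NCc1ccc(C(=O)Nc2cccc(NC(=O)COc3ccc4c(=O)ccoc4c3)c2)cc1` differs from compound 3 by a group of 10 heavy atoms (8 carbon, 1 nitrogen, 1 oxygen; one six-membered aromatic ring of carbon only) in place of a group of 9 heavy atoms (4 carbon, 2 nitrogen, 2 oxygen, 1 sulfur; one five-membered aromatic ring with 2 hetero atoms), on a nitrogen on an aromatic ring. For the measured compounds named here, two measured steps bear on this: an at least 62-fold higher number from compound 2 to compound 3 (1.79 log units; beyond the scatter) and a 2.9-fold lower number from compound 1 to compound 2 (0.46 log units; beyond the scatter). Compound 4 returns to the amide arrangement shared by compound 1 and compound 2, so a large step toward lower numbers is expected, with an at least 20-fold lower number from compound 3 to compound 4 (1.30 log units; beyond the scatter). Compound 4 is therefore estimated at 500 nM, between 100 nM and 3000 nM.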

Compound 4, half-maximal inhibitory concentration: 532 nM
The estimate for compound 4 lay 1.1-fold (0.03 log units) below the measured number; measured number inside the range.
By their numbers in this assay, from the lowest: compound 2; then compounds 1 and 4 (each within the scatter of the next). At a limit, above all of these: compound 3.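

On the nitrogen on an aromatic ring, (4-(aminomethyl)phenyl)carbonyl brings back a measured number, with an at least 18-fold lower number from compound 3 to compound 4 (1.27 log units; beyond the scatter). The value of compound 3 is a limit of the assay: the limit of > 10000 nM in this assay, at which 1 of the 4 values shown sits. On the carbonyl carbon, 4-(aminomethyl)phenyl needs no trifluoromethyl to stay level with the earlier phenyl group, with a 1.2-fold higher number from compound 1 to compound 4 (0.06 log units; within the scatter), though the thiazole keeps the lower number, with a 3.3-fold higher number from compound 2 to compound 4 (0.52 log units; beyond the scatter).

The compounds shown leave open whether the amine itself counts here. A hydroxymethyl, a carboxylic acid or a longer aminoethyl chain in its place would test that.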